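This account rests on a few compounds, and the source may have more. Where it says the series, first, only, none or still open, it means among the compounds named here.

In a functional assay on HTB-54 cells (Homo sapiens) for cytotoxicity, read by MTT assay, with a stated time of 72 h (a lower number here means a stronger inhibitor of growth, a higher number a weaker inhibitor of growth), compound 1 `C=CCOC(=O)Nc1ccc([Se]C#N)cc1` gives 27000 nM, the higher of the two numbers recorded here. Compound 2 `N#C[Se]c1ccc(NC(=O)OCC2=Cc3ccccc3S2(=O)=O)cc1` gives 6800 nM in this assay, and that gap lies beyond the usual scatter. Compound 3 `CCCCOC(=O)Nc1ccc([Se]C#N)cc1` differs from compound 1 in one place only: propyl in place of vinyl on a saturated chain carbon bound to an oxygen next to a carbonyl group. Going by the values given here, no measured pair in this set shows a step of this kind, so nothing beyond the scatter is expected in either direction. In this assay compound 3 is estimated at 25000 nM, with a range of 10000 nM to 60000 nM. That expected value amounts to a step of a 1.1-fold lower number from compound 1 to compound 3 (0.03 log units; within the scatter), within the scatter.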

Compound 3, concentration for 50% growth inhibition: 17200 nM
Compound 3: middle estimate off by 1.5-fold (0.16 log units), on the high side, within the range that was stated.
By their numbers in this assay, from the lowest: compound 2; then compounds 3 and 1 (each within the scatter of the next).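

Putting propyl in place of vinyl, on a saturated chain carbon bound to an oxygen next to a carbonyl group, gives a 1.6-fold lower number from compound 1 to compound 3 (0.20 log units; within the scatter) in this assay. Going by these compounds alone, this is the first step read at this position, and it shows that allyloxy and butoxy cannot be told apart here, so the double bond outside aromatic rings is not required for this level of growth inhibition. No measurement on hand bears on the reason for this result. Going by these compounds, whether a longer chain, an amine or a carboxylic acid at this place would shift the number beyond the scatter remains open.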